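Swapping the amide side chain of compound 2

A few compounds are considered here, and "the series" means these few. Any claim that something is new, unique, unknown or untested is made for them only; others in the source may bear on it.

Measured by an in vitro ADME assay on microsomes from Gut (Homo sapiens) for metabolic stability, using NADPH (on this read-out higher numbers stand for fast clearance and lower numbers for slow clearance), compound 2 `COc1ccc(OC(F)(F)F)cc1Cn1c(C(=O)NCC2(CO)CC2)cc2cc(C#N)ccc21` gives < 6 mL.min-1.g-1 as a limit, not a number. Compound 1 `COc1ccc(OC(F)(F)F)cc1Cn1c(C(=O)NCC(C)(C)CO)cc2cc(C#N)ccc21` gives < 6 mL.min-1.g-1 as a limit too. Compound 3 `COc1ccc(C(C)(C)C)cc1Cn1c(C(=O)NCC2(CO)CC2)cc2cc(C#N)ccc21` gives < 6 mL.min-1.g-1 as a limit too. The set therefore rests on the limit of < 6 mL.min-1.g-1 in this assay, at which 3 of the 3 values shown sit, and allows no ranking. The change to compound 4 `COc1ccc(OC(F)(F)F)cc1Cn1c(C(=O)NCC(C)(C)O)cc2cc(C#N)ccc21` is 1-hydroxy-1-methylethyl in place of 1-(hydroxymethyl)cyclopropyl on a saturated chain carbon bound to an amide-type nitrogen with 1-hydroxy-1-methylethyl taking the place of 1-(hydroxymethyl)cyclopropyl. The step at the same place is a step that the two limits leave unreadable from compound 1 to compound 2 and the other is a step that the two limits leave unreadable from compound 2 to compound 3 so neither offers a size to carry over. The expected step that the limit leaves unreadable from compound 2 to compound 4 stays within the usual scatter in this assay with no direction foreseen. For compound 4 the estimated value is 5 mL.min-1.g-1 with an expected range of 3 mL.min-1.g-1 to 10 mL.min-1.g-1 and a limit is likely.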

Compound 4, intrinsic clearance in microsomes: < 6 mL.min-1.g-1
Compound 4: a limit, no number; the forecaster's own chance of this, stated with the estimate: 80%; the middle value does not contradict the limit.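

In this assay, for the compounds shown here, compound 4 gives < 6 mL.min-1.g-1, a limit and not a number, so no step from compound 1 or compound 2 to compound 4 can be read. How fast each compound is cleared, and their ranking, stay open: the limit of < 6 mL.min-1.g-1 in this assay, at which 4 of the 4 values shown sit.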